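Swapping a methyl for a hydroxy on a triazole carboxamide

This account rests on a few compounds, and the source may have more. Where it says the series, first, only, none or still open, it means among the compounds named here.

Of the compounds shown here, three sharing one core have been tested in a functional assay on the whole organism for inhibition, with Rattus norvegicus as the target, read by paw edema, with stated times of 30 min and 4 h, at a dose of 0.28 mmol/kg by the oral route; on this read-out higher numbers stand for more inhibition at the one dose given (going by the name of the read-out) and lower numbers for less inhibition. Compound 1 `COc1ccc(NC(=O)c2nc(-c3cc(OC)c(OC)c(OC)c3)n(-c3ccc(OC)cc3)n2)cc1` gives 63%, compound 2 `COc1ccc(-n2nc(C(=O)Nc3ccc(C)cc3)nc2-c2cc(OC)c(OC)c(OC)c2)cc1` gives 58%, and compound 3 `COc1ccc(-n2nc(C(=O)Nc3ccc(C(=O)O)cc3)nc2-c2cc(OC)c(OC)c(OC)c2)cc1` gives 69%. Compound 2 therefore stands lowest of the three, although the step of a number 5 percentage points lower from compound 1 to compound 2 (within the scatter) stays within the scatter, while the step of a number 11 percentage points higher from compound 2 to compound 3 (beyond the scatter) lies beyond it. Compound 4 `COc1ccc(-n2nc(C(=O)Nc3ccc(O)cc3)nc2-c2cc(OC)c(OC)c(OC)c2)cc1` carries the change (hydroxy in place of methyl on an aromatic carbon). The nearest guide is the step to compound 3, where another oxygen-bearing group took the same place and gave a modest gain; the step to compound 1 was flat. A small rise is therefore expected in this assay, as a number 7 percentage points higher from compound 2 to compound 4 (within the scatter). Compound 4 is estimated at 65%, within 52% to 78%.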

Compound 4, a percentage reported as inhibition, in the whole organism at one dose (the size of the read-out at that dose, not a potency): 37%
The estimate for compound 4 lay 28 percentage points above the measured number; the whole stated range lies above it.
By their numbers in this assay, from the lowest: compound 4; then compounds 2, 1 and 3 (each within the scatter of the next, the first and the last beyond it).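

In this assay the hydroxy stands apart from the other groups at this position, with a number 21 percentage points lower from compound 2 to compound 4 (beyond the scatter) and a number 32 percentage points lower from compound 3 to compound 4 (beyond the scatter) for the same place, so an oxygen on the ring does not by itself hold the number up. Removing only the methyl from the oxygen of the methoxy gives a number 26 percentage points lower from compound 1 to compound 4 (beyond the scatter) and shows that the two groups are not interchangeable here. Nothing available explains this drop. As far as these compounds go, whether an amine or a hydroxymethyl at this place would fall as far remains open.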